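From ethylamino to formylamino in compound 2

The source may hold more compounds than are shown below. What is called first, only, known or untested is meant among the compounds shown, and "the series" means these compounds.

In a functional assay on the whole organism with Rattus norvegicus as the target (on this read-out lower numbers stand for an effect already at smaller amounts and higher numbers for an effect only at larger amounts of compound), compound 1 `CCN(CCNC(=O)c1cc(Cl)c(N)cc1OC)Cc1ccccn1` gives 30 mg/kg, while compound 2 `CCNc1cc(OC)c(C(=O)NC2CCN(Cc3ccccc3)C2)cc1Cl` gives 0.1 mg/kg, the lower of the two numbers, with a gap beyond the scatter. Compound 3 `COc1cc(NC=O)c(Cl)cc1C(=O)NC1CCN(Cc2ccccc2)C1` carries formyl in place of ethyl on a nitrogen on an aromatic ring. Among the compounds with values here, no measured pair shows this change, so any expectation remains tentative. A move to a higher number in this assay, beyond the scatter, is expected, and the estimated size is a 6.0-fold higher number from compound 2 to compound 3 (0.78 log units; beyond the scatter). The expected value for compound 3 is 0.6 mg/kg, with an estimated range of 0.1 mg/kg to 4 mg/kg.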

Compound 3, dose for half-maximal effect: 0.6 mg/kg
The estimate for compound 3 equals the measured number at the digits printed; low and high end bracket the measured number.
By their numbers in this assay, from the lowest: compound 2; then compound 3; then compound 1.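

In this assay, the nitrogen on an aromatic ring responds to the group it carries: formyl in place of ethyl gives a 6.0-fold higher number from compound 2 to compound 3 (0.78 log units; beyond the scatter). The change is therefore not silent, yet compound 3 still acts at 0.6 mg/kg, so ethyl is not required at this position for an effect in the rat. No measurement shown here accounts for the step. From the compounds shown here alone, it remains open how acetyl or a longer chain such as propyl would fare on the same nitrogen. Going by these compounds, whether the step carries over to the core of compound 1 is also open.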